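From hexylsulfanyl to pentyloxy on the shared core

This account rests on a few compounds, and the source may have more. Where it says the series, first, only, none or still open, it means among the compounds named here.

Compound 1 `C=CCOc1nc(N)nc2c1ncn2/C=C1/CC1(CO)CO`: > 20000 nM as a limit
Compound 2 `CCCCCCSc1nc(N)nc2c1ncn2/C=C1/CC1(CO)CO`: > 20000 nM as a limit

In an ADME assay on BCBL1 cells (Homo sapiens) for cytotoxicity, with a stated time of 7 days (on this read-out lower numbers stand for higher toxicity in this test and higher numbers for lower toxicity in this test), compound 2 gives > 20000 nM as a limit and not as a number. Going by the values given here, the one other value, that of compound 1, is also a limit, so compound 2 cannot be ranked against it.

Compound 3 `CCCCCOc1nc(N)nc2c1ncn2/C=C1/CC1(CO)CO` carries pentyloxy in place of the hexylsulfanyl of compound 2 on an aromatic carbon pentyloxy in place of hexylsulfanyl on an aromatic carbon with the rest of the shared core unchanged.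

Among the compounds with values here, only one measured step bears on this change: a step that the two limits leave unreadable from compound 1 to compound 2 with no size to carry over. Both compounds sit at the same limit of > 20000 nM in this assay, at which 2 of the 2 values shown sit, and neither gives a number in this assay for comparison. Compound 3 is therefore expected to stay in the same region, and a further limit is the likeliest report. The expected size of a number no higher from compound 2 to compound 3 (the limit leaves the size open) is no more than the usual scatter in this assay and no direction is favoured.

For compound 3 the estimated value is 20000 nM with 10000 nM as the expected lower end and 40000 nM as the expected upper end.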

Compound 3, half-maximal cytotoxic concentration: > 20000 nM
Compound 3: only a limit was reported; the forecaster's own chance of this, stated with the estimate: 75%; the middle value lies on the limit itself.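

No step can be read among compound 1, compound 2 and compound 3 in this assay, because all three are reported only as limits: the limit of > 20000 nM in this assay, at which 3 of the 3 values shown sit.

The compounds shown leave open whether allyloxy, hexylsulfanyl and pentyloxy on the shared core differ at all in half-maximal cytotoxic concentration.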